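This account rests on a few compounds, and the source may have more. Where it says the series, first, only, none or still open, it means among the compounds named here.

Compound 1 `CC(C)(F)c1ncncc1CNc1cc(N[C@H]2CC[C@@H](O)CC2)c(C#N)cn1` gives 32 nM in an assay on isolated protein for inhibition of protein kinase C delta type (Homo sapiens), read by TR-FRET, with a stated time of 2 h; a higher number here means a weaker inhibitor, a lower number a stronger inhibitor. Among the compounds with values here, compound 2 `N#Cc1cnc(NCc2cncnc2-c2ccccc2)cc1N[C@H]1CC[C@@H](O)CC1` gives 90 nM in this assay, the highest of the two numbers so far, and the step of a 2.8-fold higher number from compound 1 to compound 2 (0.45 log units; beyond the scatter) lies beyond the scatter. Compound 3 `CC(C)(C)Oc1ncncc1CNc1cc(N[C@H]2CC[C@@H](O)CC2)c(C#N)cn1` carries the change (tert-butoxy in place of phenyl on an aromatic carbon), tert-butoxy in place of phenyl on an aromatic carbon. Within the data shown here, the only step that bears on it is a 2.8-fold higher number from compound 1 to compound 2 (0.45 log units; beyond the scatter), a modest rise when phenyl entered; taking phenyl out again for a group with no ring is therefore expected to bring a modest fall, a 2.0-fold lower number from compound 2 to compound 3 (0.30 log units; within the scatter). Compound 3 is thus estimated at 45 nM in this assay, within 18 nM to 110 nM.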

Compound 3, half-maximal inhibitory concentration: 200 nM
Estimate against measurement, compound 3: 4.4-fold (0.65 log units) below, outside the stated range (above it).
By their numbers in this assay, from the lowest: compound 1; then compound 2; then compound 3.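

Taking out the phenyl ring did not lower the number in this assay at this position: tert-butoxy brought a 2.2-fold higher number from compound 2 to compound 3 (0.35 log units; beyond the scatter), leaving compound 3 the weakest of the three. Lacking a ring is therefore not enough for a low number, since two groups without a ring are separated by a 6.3-fold higher number from compound 1 to compound 3 (0.80 log units; beyond the scatter), and the oxygen-linked tert-butoxy stands on the weaker side. No evidence is at hand to explain these steps. On these data alone, whether methoxy or an amine on this aromatic carbon would fall nearer compound 1 or compound 3 stays open.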